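Cytotoxicity limits across the shared-core amide series

The source may report more compounds than this note shows. Statements on the series, on what has been measured and on what is new or still open speak of the compounds shown alone.

Compound 3 `CCCc1ccc(C(=O)Nc2cc3nc(C4CCCCC4)[nH]c3cc2N(C)C)cc1` is one of three members of the series with a value in an ADME assay on Vero cells (Chlorocebus sabaeus) for cytotoxicity, read by resazurin assay, with a stated time of 3 days; a higher number here means a weaker inhibitor, a lower number a stronger inhibitor. In this assay compound 3 gives > 100 ug/mL, which is a limit of the assay and not a number. Compound 1 `COc1ccc(C(=O)Nc2cc3nc(C4CCCCC4)[nH]c3cc2N(C)C)cc1` also sits at a limit, giving > 100 ug/mL in this assay. Compound 2 `CCCCOC(=O)Nc1cc2nc(C3CCCCC3)[nH]c2cc1N(CCC)CCC` gives > 100 ug/mL in this assay, again a limit. The step that the two limits leave unreadable from compound 1 to compound 3, propyl in place of methoxy on an aromatic carbon, cannot be read, both ends sitting at the limit of > 100 ug/mL in this assay, at which 3 of the 3 values shown sit. Compound 4 `CCc1ccc(C(=O)Nc2cc3nc(C4CCCCC4)[nH]c3cc2N(C)C)cc1` differs from compound 3 by hydrogen in place of methyl on a saturated chain carbon, two bonds along the chain from an aromatic carbon, which cut one bond further out reads propyl to ethyl or 4-propylphenyl to 4-ethylphenyl. For the measured compounds named here, no measured step offers a readable size for this change, and all three values shown sit at the same limit. Compound 4 is expected to stay at that limit as well, the expected step that the limit leaves unreadable from compound 3 to compound 4 meaning no change beyond the scatter, resting on the limit of > 100 ug/mL in this assay, at which 3 of the 3 values shown sit, where compound 3 sits. The estimate for compound 4 in this assay is 150 ug/mL, between 100 ug/mL and 300 ug/mL.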

Compound 4, half-maximal inhibitory concentration: > 100 ug/mL
Compound 4: a limit, no number; the forecaster's own chance of this, stated with the estimate: 90%; the middle value does not contradict the limit.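

Compound 4 gives > 100 ug/mL in this assay, a limit and not a number. No new step can be read from compound 3 or compound 1 to compound 4, as both ends of each sit at a limit: the limit of > 100 ug/mL in this assay, at which 4 of the 4 values shown sit. The compounds shown leave open how far any of these changes moves the read-out in this assay, as none of them has a numerical value.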